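This account rests on a few compounds, and the source may have more. Where it says the series, first, only, none or still open, it means among the compounds named here.

Working notes on the series, with all values from an ADME assay on HEp-2 cells (Homo sapiens) for cytotoxicity; on this read-out higher numbers stand for lower toxicity in this test and lower numbers for higher toxicity in this test. Compound 1 `CC(C)CCn1c(Cn2c(=O)n(C(C)C)c3ccccc32)nc2cc(CNC3CC3)ccc21` gives 17200 nM, compound 2 `CC(C)CCn1c(Cn2c(=O)n(C(C)C)c3ccccc32)nc2cc(C(C)(C)N)ccc21` gives 3270 nM, and compound 3 `C=Cc1ccc2c(c1)nc(Cn1c(=O)n(C(C)C)c3ccccc31)n2CCC(C)C` gives 6520 nM. Compound 3 cannot be separated from its nearest neighbour, a 2.0-fold higher number from compound 2 to compound 3 (0.30 log units; within the scatter), and its furthest gap is a 2.6-fold lower number from compound 1 to compound 3 (0.42 log units; beyond the scatter).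

Compound 4 `CCc1ccc2c(c1)nc(Cn1c(=O)n(C(C)C)c3ccccc31)n2CCC(C)C` carries ethyl in place of vinyl on an aromatic carbon. All three measured steps change the group at this same place, so all three bear on the new step. The largest of them is modest, a 5.3-fold lower number from compound 1 to compound 2 (0.72 log units; beyond the scatter). None of them, however, is an exchange as small as this one, and the data hold no direct vinyl to ethyl comparison. The closest guide is the step between the two compounds nearest in value, which stays within the scatter. No step beyond the scatter is therefore expected in this assay, and the expected change is a 1.1-fold lower number from compound 3 to compound 4 (0.04 log units; within the scatter). For compound 4 the estimated value is 6000 nM, with an expected range of 3000 nM to 12000 nM.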

Compound 4, half-maximal cytotoxic concentration: 18500 nM
Compound 4: the middle estimate sits 3.1-fold (0.49 log units) below what was measured; measured number above the stated range.
By their numbers in this assay, from the lowest: compounds 2 and 3 (each within the scatter of the next); then compounds 1 and 4 (each within the scatter of the next).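

Vinyl and ethyl have the same count of heavy atoms and differ here only in the double bond outside aromatic rings, yet this exchange on the aromatic carbon gives a step beyond the scatter in this assay (a 2.8-fold higher number from compound 3 to compound 4 (0.45 log units; beyond the scatter)), so even the smallest change so far at this position registers. Ethyl, which carries no amine, cannot be separated from the amine-bearing group of compound 1 (a 1.1-fold higher number from compound 1 to compound 4 (0.03 log units; within the scatter)) but stands well clear of the amine-bearing group of compound 2 (a 5.7-fold higher number from compound 2 to compound 4 (0.75 log units; beyond the scatter)), so an amine at this place does not by itself set the number. No measurement available here accounts for these steps.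

Open, from the compounds shown here alone, is whether a longer saturated chain such as propyl stays with ethyl, and whether an alkyne such as ethynyl falls with vinyl.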